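A few compounds are considered here, and "the series" means these few. Any claim that something is new, unique, unknown or untested is made for them only; others in the source may bear on it.

For the measured compounds named here, compound 2 `C[C@H](NC(=O)c1ccc(Cl)cc1O)C(=O)Nc1ccc(Cl)cc1` is one of two compounds measured in a functional assay on MCF7 cells (Homo sapiens) for cytotoxicity, with a stated time of 72 h; a lower number here means a stronger inhibitor, a higher number a weaker inhibitor. For compound 2 that assay returns only a limit, > 10000 nM, which is the limit of > 10000 nM in this assay, at which 1 of the 2 values shown sits. Compound 1 `C[C@H](NC(=O)c1ccc(Cl)cc1O)C(=O)Nc1ccc(C(F)(F)F)cc1` differs from compound 2 at a single place, a trifluoromethyl in place of the chloro on an aromatic carbon. In this assay compound 1 also gives only a limit, > 12500 nM, which is the limit of > 12500 nM in this assay, at which 1 of the 2 values shown sits. Going by the values given here, the one measured step, a step that the two limits leave unreadable from compound 1 to compound 2, therefore has no readable size, and neither compound shows a potency this assay can resolve.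

Compound 3 `C[C@@H](NC(=O)c1ccc(Cl)cc1O)C(=O)Nc1ccc(Cl)cc1` is the next compound. Between compound 2 and compound 3 the change is the two compounds have the same atoms and bonds and differ only in configuration as drawn: 1 of 1 stereo elements differ; a stereocentre at a saturated chain carbon is drawn S in compound 2 and R in compound 3. No measured step touches a stereocentre, so nothing shown here tells how far an inversion of configuration can move this assay; the only guide is that compound 2 sits at a limit. Compound 3 is therefore expected, in this assay, to give a result near that limit, an estimated 15000 nM with a range from 4000 nM to 60000 nM. The expected step is a step that the limit leaves unreadable from compound 2 to compound 3, with a good chance that this assay again reports only a limit rather than a number.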

Compound 3, half-maximal inhibitory concentration: > 10000 nM
Compound 3 was reported as a limit; the forecaster's own chance of this, stated with the estimate: 75%; the middle value does not contradict the limit.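

For the compounds shown here, compound 2 and compound 3 both stop at a limit in this assay and so the inversion of configuration gives no step of readable size: the limit of > 10000 nM in this assay, at which 2 of the 3 values shown sit. The compounds shown leave open whether either configuration, or the chloro or trifluoromethyl compound, has a potency that this assay can resolve as a number.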